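This account rests on a few compounds, and the source may have more. Where it says the series, first, only, none or still open, it means among the compounds named here.

Compound 1 `COc1ccc(C(=O)c2cc(OC)c(OC)c(OC)c2)cc1N` gives 60 nM in a functional assay on HeLa cells (Homo sapiens) for cytotoxicity, read by MTT assay, with a stated time of 72 h; on this read-out higher numbers stand for weaker inhibition and lower numbers for stronger inhibition. Compound 2 `COc1ccc(/C=C/C(=O)Nc2cc(C(=O)c3cc(OC)c(OC)c(OC)c3)ccc2OC)cc1` gives 10700 nM in this assay. Compound 3 `COc1ccc(C(=O)c2cc(OC)c(OC)c(OC)c2)cc1NC(=O)/C=C/c1ccc(F)cc1` gives 60 nM in this assay: level with compound 1 at the digits shown and together the lowest of the three, the step of no change at the digits printed from compound 1 to compound 3 (within the scatter) lying within the scatter, while the step of a 180-fold lower number from compound 2 to compound 3 (2.25 log units; beyond the scatter) sets it far apart from compound 2. Compound 4 `COc1ccc(C(=O)c2cc(OC)c(OC)c(OC)c2)cc1NC(=O)/C=C/c1cccc(OC(F)(F)F)c1` carries 3-(trifluoromethoxy)phenyl in place of 4-fluorophenyl on a double-bonded chain carbon bound to a double-bonded chain carbon. Within the data shown here, the step of a 180-fold lower number from compound 2 to compound 3 (2.25 log units; beyond the scatter) bears on this, as it too alters the group on the double-bonded chain carbon; no measured step tests a trifluoromethoxy group. The expected step is a 5.0-fold higher number from compound 3 to compound 4 (0.70 log units; beyond the scatter), toward a higher number with wide uncertainty. Compound 4 is estimated at 300 nM, range 40 nM to 3000 nM.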

Compound 4, half-maximal inhibitory concentration: 7900 nM
For compound 4 the middle estimate is 26-fold (1.42 log units) below the measured one; the measured number lies above the stated range.
By their numbers in this assay, from the lowest: compounds 1 and 3 (each within the scatter of the next); then compounds 4 and 2 (each within the scatter of the next).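

In this assay the low number at this position does not carry over from 4-fluorophenyl to 3-(trifluoromethoxy)phenyl: the change gives a 130-fold higher number from compound 3 to compound 4 (2.12 log units; beyond the scatter) and so removes what compound 3 held. Against 4-methoxyphenyl, the same group gives a 1.4-fold lower number from compound 2 to compound 4 (0.13 log units; within the scatter) and leaves compound 2 and compound 4 level, so among the three amides only compound 3 stands apart. No measurement at hand accounts for either step.

Still open, going by these compounds, is whether the step follows the trifluoromethoxy group itself or its place on the ring. Also open, on these data alone, is how a ring carrying an amine or a carboxylic acid would read here.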